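A few compounds are considered here, and "the series" means these few. Any claim that something is new, unique, unknown or untested is made for them only; others in the source may bear on it.

Measured compounds:
compound 1 `Cc1cc(NCCCc2ccccn2)n2nc(C)c(-c3ccccc3)c2n1`: 5900 nM
compound 2 `Cc1cc(NCc2ccccn2)n2ncc(-c3ccsc3)c2n1`: 9000 nM

In a physicochemical assay for solubility, read by HPLC, using the shake flask method, measured as kinetic solubility, with a stated time of 2 h, at pH 7.4 (on this read-out higher numbers stand for higher solubility and lower numbers for lower solubility), compound 1 gives 5900 nM, the lowest of the two numbers on hand. Compound 2 gives 9000 nM in this assay, and the gap between the two lies within the scatter, so neither can be placed above the other. Among the measured compounds shown here, no step between measured compounds that differ in one place is available, so nothing measured anchors the move to compound 3 `CCN1CCCC1CNc1cc(C)nc2c(-c3ccccc3)c(C)nn12`. Relative to compound 1 the change is 1-ethylpyrrolidin-2-yl in place of 2-(pyridin-2-yl)ethyl on a saturated chain carbon bound to a nitrogen on an aromatic ring. For the measured compounds named here, with no measured step of this kind to lean on, a modest rise in this assay is expected rather than a fall or a flat result within the scatter. The expected size of the step is a 2.5-fold higher number from compound 1 to compound 3 (0.41 log units; beyond the scatter). Compound 3 is thus expected to give 15000 nM in this assay, within a range of 5000 nM to 45000 nM.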

Compound 3, solubility: 172000 nM
For compound 3 the middle estimate is 11-fold (1.06 log units) below the measured one; measured number above the stated range.
By their numbers in this assay, from the lowest: compounds 1 and 2 (each within the scatter of the next); then compound 3.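

In this assay, among the compounds shown here, the position on a saturated chain carbon bound to a nitrogen on an aromatic ring turns out to be highly sensitive: 1-ethylpyrrolidin-2-yl in place of 2-(pyridin-2-yl)ethyl gives a 29-fold higher number from compound 1 to compound 3 (1.46 log units; beyond the scatter) and so opens the first step of any kind. The six-membered aromatic ring with 1 hetero atom gives way to a five-membered non-aromatic ring with 1 hetero atom, while the hydrogen-bond donor and acceptor counts stay the same, so those counts do not separate the two groups. Nothing on hand accounts for the size of this step.

On these data alone, whether the ring, the chain or the ethyl group carries the step remains open. Also open, as far as these compounds go, is whether a morpholine or a piperidine at this place would give a step of similar size.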